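Methylsulfonyl to 1,1-difluoroethyl: an expected stability read-out

This account rests on a few compounds, and the source may have more. Where it says the series, first, only, none or still open, it means among the compounds named here.

Measured compounds:
- compound 1, `O=C(C[C@H](CCN1CCCCC1)NC(=O)c1cc(-c2ccccc2C2CC2)n(C2CCCC2)n1)NC1CCC1`, 70.1%
- compound 2, `CS(=O)(=O)c1ccccc1-c1cc(C(=O)N[C@@H](CCN2CCCCC2)CC(=O)NC2CCC2)nn1C1CCCC1`, "nd" (no result reported)

Going by the values given here, compound 1 is the only member of this small set with a number in an ADME assay on microsomes from liver (Rattus norvegicus, strain Sprague-Dawley) for metabolic stability, read by LC-MS, using NADPH, with a stated time of 30 min, tested at 1 uM (on this read-out higher numbers stand for a more stable compound and lower numbers for a less stable compound), where compound 1 gives 70.1%. Compound 2 shares the core of compound 1 but carries a methylsulfonyl group on its outer six-membered aromatic ring; in this assay compound 2 is reported as "nd" (no result reported), that is, it has no single number, so it offers no foothold for judging how far any neighbour departs from it.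

Compound 3 is `CC(F)(F)c1ccccc1-c1cc(C(=O)N[C@@H](CCN2CCCCC2)CC(=O)NC2CCC2)nn1C1CCCC1`. Its difference from compound 2 is 1,1-difluoroethyl in place of methylsulfonyl on an aromatic carbon. Among the compounds with values here, with no measured pair sharing this change, the size of the step cannot be read from the data; a shift in either direction beyond the usual scatter is possible, as is none at all.

On that basis compound 3 is expected to give about 55% in this assay, estimated to lie between 25% and 85%.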

Compound 3, percent of the compound remaining: 77.1%
Compound 3: the middle estimate sits 22.1 percentage points below what was measured, and the stated range covers the measured number.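

In this assay, going by these compounds alone, the swap of cyclopropyl for 1,1-difluoroethyl on an aromatic carbon gives a number 7 percentage points higher from compound 1 to compound 3 (within the scatter) and so offers the first comparison at this position, where these two groups cannot be told apart on this read-out. Compound 2 has no number, so the step from it to compound 3 cannot be read, and the data do not show how methylsulfonyl compares with either group. Nothing measured here explains the result.

The compounds shown leave open whether a group of a different kind on this aromatic carbon, such as an amine or a carboxylic acid, would give a number close to those of compound 1 and compound 3. They also leave open whether a smaller group, such as a single fluorine, would do so.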